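This account rests on a few compounds, and the source may have more. Where it says the series, first, only, none or still open, it means among the compounds named here.

In a functional assay on MCF7 cells (Homo sapiens) for inhibition, read by MTT assay, with a stated time of 24 h (a higher number here means a weaker inhibitor, a lower number a stronger inhibitor), the measured compounds stand as follows.

Compound 1 `CCOC(=O)C1=Cc2ccccc2OC1(OCc1cc(-c2ccc3ccccc3c2)no1)C(F)(F)F`: 65400 nM
Compound 3 `CCOC(=O)C1=Cc2ccccc2OC1(OCc1cn(-c2ccc(F)c(Cl)c2)nn1)C(F)(F)F`: 25300 nM
Compound 2 `O=C(O)C1=Cc2ccccc2OC1(OCc1cc(-c2ccc3ccccc3c2)no1)C(F)(F)F`: a limit rather than a number, > 150000 nM

Compound 1 gives the highest of the two plain numbers, compound 3 sitting lower. Within the data shown here, the only single-point step measured is an at least 2.2-fold higher number from compound 1 to compound 2 (0.36 log units; beyond the scatter), which concerns the ester end of the molecule and not the aryl group, so it carries no direct information on the change at hand. Compound 4 `CCOC(=O)C1=Cc2ccccc2OC1(OCc1cc(-c2cccc(C(F)(F)F)c2)no1)C(F)(F)F` differs from compound 1 by 3-(trifluoromethyl)phenyl in place of naphthalen-2-yl on an aromatic carbon. Among the measured compounds shown here, compound 3 shows a different aryl group on a different five-membered ring, with other changes besides, so it offers no clean precedent either. For the measured compounds named here, with no measured step bearing on this exchange, compound 4 is expected to stay near compound 1, with a 1.3-fold lower number from compound 1 to compound 4 (0.12 log units; within the scatter), and an estimate of 50000 nM (range 18000 nM to 150000 nM).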

Compound 4, half-maximal inhibitory concentration: 22100 nM
Compound 4: middle estimate off by 2.3-fold (0.35 log units), on the high side, within the range that was stated.
By their numbers in this assay, from the lowest: compounds 4 and 3 (each within the scatter of the next); then compound 1. At a limit, above all of these: compound 2.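

In this assay the aromatic carbon next to the ring nitrogen responds to the group it carries: 3-(trifluoromethyl)phenyl in place of naphthalen-2-yl gives a 3.0-fold lower number from compound 1 to compound 4 (0.47 log units; beyond the scatter). The two aromatic rings of naphthalen-2-yl are therefore not needed for this level of inhibition, since one ring bearing trifluoromethyl gives a lower number. Nothing shown explains why this exchange lowers the number.

On these data alone, whether the change comes from the trifluoromethyl group or from having one ring instead of two remains open. How a plain phenyl, or a phenyl bearing an amine, would compare is also unknown.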